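The compounds below may be only part of what the source reports. "The series", "measured", "known", "first", "only" and "open" are said of these compounds alone.

Working notes on the series, read in a toxicity assay on Vero cells (Chlorocebus sabaeus) for cytotoxicity, read by MTT assay; on this read-out lower numbers stand for stronger inhibition and higher numbers for weaker inhibition. Compound 1 `COC(=O)NC(=O)c1ccsc1NC(=O)c1ccc(S(=O)(=O)N2CCC(c3ccccc3)CC2)cc1` gives "nd" (no result reported) and compound 2 `O=C(NC(=O)c1ccsc1NC(=O)c1ccc(S(=O)(=O)N2CCCCC2)cc1)OCC(F)(F)F` gives "nd" (no result reported), so neither provides a number. Going by the values given here, compound 3 `CC(C)OC(=O)NC(=O)c1ccsc1NC(=O)c1ccc(S(=O)(=O)N2CCOCC2)cc1` gives 13.1 ug/mL, the only number so far, which leaves it unranked against the others.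

Compound 4 `Cc1ccnc(NC(=O)c2ccsc2NC(=O)c2ccc(S(=O)(=O)N3CCOCC3)cc2)n1` has no reading yet. It differs from compound 3 as follows: 4-methylpyrimidin-2-yl in place of isopropoxycarbonyl on an amide-type nitrogen. In words, 4-methylpyrimidin-2-yl stands in place of isopropoxycarbonyl on an amide-type nitrogen.

Among the compounds with values here, no pair of measured compounds shows what a change at this place does, and no measured compound carries 4-methylpyrimidin-2-yl. Within the data shown here, the only anchor is compound 3 at 13.1 ug/mL, which supports no direction, so no change beyond the scatter is expected. The expected step is a 1.0-fold lower number from compound 3 to compound 4 (0.00 log units; within the scatter), and the range stays wide given this single anchor. For compound 4 the estimated value is 13 ug/mL, with an expected range of 4 ug/mL to 45 ug/mL.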

Compound 4, half-maximal inhibitory concentration: 42.7 ug/mL
For compound 4 the middle estimate is 3.3-fold (0.52 log units) below the measured one; measured number inside the range.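

In this assay, this amide-type nitrogen now shows that the read-out responds to the group it carries: 4-methylpyrimidin-2-yl in place of isopropoxycarbonyl gives a 3.3-fold higher number from compound 3 to compound 4 (0.51 log units; beyond the scatter), a shift towards weaker inhibition. The entering group brings a six-membered aromatic ring where the leaving group has none, while the counts of hydrogen-bond donors and acceptors are the same, so those counts do not separate compound 3 from compound 4. No supporting measurement bears on what drives the step.

From the compounds shown here alone, with one pair, it remains open whether the shift follows the arrival of the ring or the loss of the carbonyl, which an acetyl or a pyridin-2-yl group on the same nitrogen would help separate. Also open, going by these compounds, is whether a longer chain such as butoxycarbonyl would read nearer compound 3 or compound 4.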